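The source may hold more compounds than are shown below. What is called first, only, known or untested is meant among the compounds shown, and "the series" means these compounds.

Series notes. Compound 1 `CS(=O)(=O)c1ccc(C(=O)N2CCC(C(=O)N3CCc4ccccc43)CC2)cc1[N+](=O)[O-]` has been run in an ADME assay on HepG2 cells (Homo sapiens) for cytotoxicity, read by CellTiter-Glo and ATP content, with a stated time of 72 h (on this read-out lower numbers stand for an effect already at smaller amounts and higher numbers for an effect only at larger amounts of compound), where compound 1 returns > 27000 nM, which is a limit of the assay and not a number. Compound 1 therefore stands at the limit of > 27000 nM in this assay, at which 1 of the 3 values shown sits. Compound 2 `CN(Cc1ccccc1F)C(=O)CNC(=O)c1ccc(S(C)(=O)=O)c([N+](=O)[O-])c1` gives in this assay 11400 nM, and compound 3 `CN(CC(=O)N1CCN(c2ccc(F)cc2)CC1)C(=O)c1ccc(S(C)(=O)=O)c([N+](=O)[O-])c1` gives 17200 nM. Compound 4 `CN1CCN(C(=O)C2CCN(C(=O)c3ccc(S(C)(=O)=O)c([N+](=O)[O-])c3)CC2)CC1` is not yet measured; its change from compound 1 is 4-methylpiperazin-1-yl in place of 2,3-dihydro-1H-indol-1-yl on a carbonyl carbon, in words 4-methylpiperazin-1-yl in place of 2,3-dihydro-1H-indol-1-yl on a carbonyl carbon. For the measured compounds named here, no measured pair in the set differs in one place, so no step size is known. The expected step from compound 1 to compound 4 in this assay is a step that the limit leaves unreadable from compound 1 to compound 4, none beyond the scatter. The estimate for compound 4 in this assay is 30000 nM, with a range from 14000 nM to 65000 nM, and a limit is the more likely outcome.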

Compound 4, half-maximal effective concentration: > 27000 nM
Compound 4: only a limit was reported (the forecaster's own chance of this, stated with the estimate: 65%); the middle value does not contradict the limit.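

No step can be read from compound 1 to compound 4, since both results in this assay are limits and not numbers: the limit of > 27000 nM in this assay, at which 2 of the 4 values shown sit.

The compounds shown leave open whether 4-methylpiperazin-1-yl in place of 2,3-dihydro-1H-indol-1-yl on a carbonyl carbon changes the read-out at all.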